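Swapping 1-acetamidoethyl for 2-cyanoethyl on the shared core

This account rests on a few compounds, and the source may have more. Where it says the series, first, only, none or still open, it means among the compounds named here.

Values in a physicochemical assay for solubility, measured as kinetic solubility, with a stated time of 1 h, at pH 7.4 (a higher number here means a more soluble compound, a lower number a less soluble compound), so far
compound 1 `CC(=O)NC1=NN(c2ccc(Cl)c(Cl)c2)CC1` gives 31000 nM
compound 2 `N#CCC(=O)NC1=NN(c2ccc(Cl)c(Cl)c2)CC1` gives 202000 nM
compound 3 `CC(=O)N[C@@H](C)C(=O)NC1=NN(c2ccc(Cl)c(Cl)c2)CC1` gives 58000 nM

Compound 3 stands clearly apart only from compound 2, since the modest step of a 3.5-fold lower number from compound 2 to compound 3 (0.54 log units; beyond the scatter) lies beyond the scatter. The step of a 1.9-fold higher number from compound 1 to compound 3 (0.27 log units; within the scatter) stays within the scatter, so compound 1 and compound 3 cannot be told apart.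

The next compound is compound 4 `N#CCCC(=O)NC1=NN(c2ccc(Cl)c(Cl)c2)CC1`, which keeps the shared core. On the carbonyl carbon, 2-cyanoethyl takes the place of 1-acetamidoethyl (2-cyanoethyl in place of 1-acetamidoethyl on a carbonyl carbon). Within the data shown here, the new chain carries a nitrile, as the cyanomethyl chain of compound 2 does, but no measured compound has 2-cyanoethyl itself.

Among the measured compounds shown here, two measured steps bear on this. The step of a 6.5-fold higher number from compound 1 to compound 2 (0.81 log units; beyond the scatter) shows a modest gain when a cyano group appears on the chain, and the step of a 3.5-fold lower number from compound 2 to compound 3 (0.54 log units; beyond the scatter) is the nearest match to the present exchange, though it starts from cyanomethyl. A small rise in this assay is therefore expected, probably smaller than the full gap to compound 2. The expected change is a 2.1-fold higher number from compound 3 to compound 4 (0.32 log units; beyond the scatter) as an estimate, and it is uncertain. For compound 4 the estimated value is 120000 nM (range 45000 nM to 250000 nM).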

Compound 4, solubility: 39000 nM
The estimate for compound 4 lay 3.1-fold (0.49 log units) above the measured number; measured number outside the range, below it.
By their numbers in this assay, from the lowest: compounds 1, 4 and 3 (each within the scatter of the next); then compound 2.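

In this assay, the step of a 5.2-fold lower number from compound 2 to compound 4 (0.71 log units; beyond the scatter) shows that a nitrile on the chain does not by itself bring the high number seen for compound 2: with 2-cyanoethyl on the carbonyl carbon in place of cyanomethyl, that number is not kept. The steps of a 1.3-fold higher number from compound 1 to compound 4 (0.10 log units; within the scatter) and a 1.5-fold lower number from compound 3 to compound 4 (0.17 log units; within the scatter) place compound 4 level with both compound 1 and compound 3, so methyl, 1-acetamidoethyl and 2-cyanoethyl cannot be told apart at this position, and among the four compounds only cyanomethyl stands clear of the others. No measurement offered here explains why cyanomethyl and 2-cyanoethyl part so clearly in this assay.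

From the compounds shown here alone, it remains open whether compound 2 is a lone high point or the start of a trend that a different chain could extend, such as a branched chain bearing a nitrile or a longer one like 3-cyanopropyl. Going by these compounds, how a chain ending in an amine or a carboxylic acid would compare on the same core also stays unknown.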